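Propyl in Place of Chloro on an Aromatic Carbon

A few compounds are considered here, and "the series" means these few. Any claim that something is new, unique, unknown or untested is made for them only; others in the source may bear on it.

Compound 1 `Cc1cccc(CCCCCCC(=O)N2CCCC2)c1`: 8300 nM
Compound 2 `O=C(CCCCCCc1ccc(Cl)cc1)N1CCCC1`: 34500 nM
Compound 3 `O=C(O)c1cccc(CCCCCCC(=O)N2CCCC2)c1`: > 100000 nM, a limit of the assay

In an assay on HEK293 cells for inhibition of N-acylethanolamine-hydrolyzing acid amidase (Rattus norvegicus), read by LC-MS, with a stated time of 30 min (a lower number here means a stronger inhibitor, a higher number a weaker inhibitor), compound 2 gives 34500 nM, the highest of the two numbers measured; its nearest neighbour is compound 1, which gives a lower number. Compound 3 reaches only a limit of the assay, > 100000 nM. For the measured compounds named here, the single step between measured compounds, an at least 12-fold higher number from compound 1 to compound 3 (1.08 log units; beyond the scatter), exchanges methyl for carboxy and ends at the limit of > 100000 nM in this assay, at which 1 of the 3 values shown sits. Compound 4 `CCCc1ccc(CCCCCCC(=O)N2CCCC2)cc1` differs from compound 2 by propyl in place of chloro on an aromatic carbon. Going by the values given here, no measured step exchanges chloro for an alkyl group, so the step from compound 1 to compound 3 bears only loosely on this change: it shows that a substituent on that ring can move the number far, though there towards weaker inhibition, whereas propyl is closer in kind to the methyl of compound 1, whose number is lower than that of compound 2. Compound 4 is therefore expected to give 15000 nM, between 4000 nM and 60000 nM, an expected step of a 2.3-fold lower number from compound 2 to compound 4 (0.36 log units; beyond the scatter).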

Compound 4, half-maximal inhibitory concentration: > 100000 nM
Compound 4 was reported as a limit (the forecaster's own chance of this, stated with the estimate: 10%); middle value at least 6.6-fold (0.82 log units) from the limit.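

In this assay, propyl in place of chloro on an aromatic carbon para to a large group gives an at least 2.8-fold higher number from compound 2 to compound 4 (0.46 log units; beyond the scatter), so at this position the alkyl group moves the number towards weaker inhibition, not towards stronger. The value of compound 4, > 100000 nM, is a limit of the assay. Until now only compound 3, with carboxy, stood at that limit, and a compound carrying a plain alkyl group now joins it: the limit of > 100000 nM in this assay, at which 2 of the 4 values shown sit.

What ethyl or methyl on this same carbon would give stays open, so the compounds shown do not tell at what chain length the number climbs away from that of compound 2. Nor do they tell how an amine or a methoxy group here would compare with chloro.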